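The source may hold more compounds than are shown below. What is called first, only, known or untested is meant among the compounds shown, and "the series" means these compounds.

Three compounds built on one shared core were tested in an ADME assay on A549 cells (Homo sapiens) for cytotoxicity, read by resazurin assay, with a stated time of 48 h; on this read-out higher numbers stand for lower toxicity in this test and lower numbers for higher toxicity in this test. Compound 1 `CC(C)Nc1ccc(NC(=O)c2cc(Cl)ccc2O)c(Cl)c1` gives 11000 nM. Compound 2 `CC1(Nc2ccc(NC(=O)c3cc(Cl)ccc3O)c(Cl)c2)CCCC1` gives 157000 nM, and compound 3 `O=C(Nc1ccc(NCc2cccc(Br)n2)cc1Cl)c1cc(Cl)ccc1O` gives 92300 nM. Compound 2 stands at the highest of the three numbers, though only its gap to compound 1 is beyond the scatter: the step of a 14-fold higher number from compound 1 to compound 2 (1.15 log units; beyond the scatter) is large, whereas the step of a 1.7-fold lower number from compound 2 to compound 3 (0.23 log units; within the scatter) is within the scatter. The step of an 8.4-fold higher number from compound 1 to compound 3 (0.92 log units; beyond the scatter) is modest.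

Compound 4 `O=C(Nc1ccc(NCc2ccc(O)nc2)cc1Cl)c1cc(Cl)ccc1O` differs from compound 2 in one place: (6-hydroxypyridin-3-yl)methyl in place of 1-methylcyclopentyl on a nitrogen on an aromatic ring. The measured step that bears most directly on this change is a 1.7-fold lower number from compound 2 to compound 3 (0.23 log units; within the scatter), in which a pyridinylmethyl group likewise took the place of 1-methylcyclopentyl on the same nitrogen, and that step stayed within the scatter. The two steps starting from compound 1 show that a change at this nitrogen can move the number considerably, but in both of them isopropyl is the group that leaves, not 1-methylcyclopentyl. On this basis the number for compound 4 in this assay is expected to remain near that of compound 2, with the step of a 1.6-fold lower number from compound 2 to compound 4 (0.20 log units; within the scatter) expected to fall within the scatter. The estimate for compound 4 is 100000 nM, with a range from 40000 nM to 250000 nM.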

Compound 4, half-maximal cytotoxic concentration: 98500 nM
Compound 4: middle estimate off by 1.0-fold (0.01 log units), on the high side, and the stated range covers the measured number.
By their numbers in this assay, from the lowest: compound 1; then compounds 3, 4 and 2 (each within the scatter of the next).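

In this assay the step of a 1.6-fold lower number from compound 2 to compound 4 (0.20 log units; within the scatter) shows that 1-methylcyclopentyl on this nitrogen can give way to (6-hydroxypyridin-3-yl)methyl, which brings an aromatic ring with a hetero atom and adds hydrogen-bond donor and acceptor counts, without a move beyond the scatter. The step of a 1.1-fold higher number from compound 3 to compound 4 (0.03 log units; within the scatter) adds that 6-hydroxypyridin-3-yl in place of 6-bromopyridin-2-yl on the saturated chain carbon also stays within the scatter, so these two pyridine-bearing groups are not told apart here. With a 9.0-fold higher number from compound 1 to compound 4 (0.95 log units; beyond the scatter) as its third step beyond the scatter from isopropyl, compound 1 now stands apart from all three other compounds, while compounds 2, 3 and 4 form one group.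

On these data alone, whether a small group such as methyl or cyclopropyl, or a chain ending in a carboxylic acid or an amine, would fall with compound 1 or with the other three stays open. No supporting data are available to explain why isopropyl stands apart from the three larger groups.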